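Swapping the side chain in a small series

The compounds below may be only part of what the source reports. "The series", "measured", "known", "first", "only" and "open" are said of these compounds alone.

Two compounds have been measured in a functional assay on the whole organism (Tail, strain ICR) with Mus musculus as the target, in the tail flick test, with a stated time of 90 min, at a dose of 25 umol/kg by the oral route; on this read-out lower numbers stand for a weaker effect and higher numbers for a stronger effect at the one dose given:
compound 1 `O=C(CN(c1nc(Cl)nc2[nH]cnc12)C1CC1)N[C@@H](CC(=O)OCc1ccccc1)C(=O)OCc1ccccc1` gives 15.6%;
compound 2 `CC[C@H](C)[C@H](NC(=O)CN(c1nc(Cl)nc2[nH]cnc12)C1CC1)C(=O)OCc1ccccc1` gives 36.3%.

Compound 2 stands highest of the two numbers, its nearest neighbour being compound 1, separated by the step of a number 20.7 percentage points higher from compound 1 to compound 2 (beyond the scatter). Compound 3 `NC(=O)C[C@H](NC(=O)CN(c1nc(Cl)nc2[nH]cnc12)C1CC1)C(=O)OCc1ccccc1` differs from compound 2 by carbamoylmethyl in place of sec-butyl on a saturated chain carbon bound to an amide-type nitrogen and a carbonyl carbon. Within the data shown here, only one measured step bears on this change, the exchange of a group at the same place from compound 1 to compound 2, which was of modest size. For compound 3 a downward step a number 16.3 percentage points lower from compound 2 to compound 3 (beyond the scatter) is therefore expected. Compound 3 is estimated at 20%, within the range 5% to 38%.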

Compound 3, a percentage reported as activity, at one dose (the size of the read-out at that dose, not a potency): 32.3%
For compound 3 the middle estimate is 12.3 percentage points below the measured one, and the stated range covers the measured number.
By their numbers in this assay, from the lowest: compound 1; then compounds 3 and 2 (each within the scatter of the next).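

In this assay, carbamoylmethyl on the saturated chain carbon bound to an amide-type nitrogen and a carbonyl carbon gives a read-out much like that of sec-butyl, with a number 4 percentage points lower from compound 2 to compound 3 (within the scatter), although only carbamoylmethyl carries a hydrogen-bond donor and acceptor. Amino in place of benzyloxy on a carbonyl carbon gives a number 16.7 percentage points higher from compound 1 to compound 3 (beyond the scatter), so this single exchange separates compound 1 from compound 3. Nothing available explains either result. The compounds shown leave open how a carboxylic acid or an amine at this position would read, and how a longer chain would compare with sec-butyl.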